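The compounds below may be only part of what the source reports. "The series", "measured", "known", "first", "only" and "open" are said of these compounds alone.

Compound 1 `FC(F)(F)c1ccc(-c2ccc3c(NCCCNCc4ccco4)ccnc3c2)cc1` is one of three compounds with a number in an ADME assay on HepG2 cells (Homo sapiens) for cytotoxicity, read by luminescence, CellTiter-Glo and ATP content, with a stated time of 72 h; on this read-out lower numbers stand for an effect already at smaller amounts and higher numbers for an effect only at larger amounts of compound. In this assay compound 1 gives 3470 nM, the lowest of the three numbers. Compound 3 `COc1ccc(-c2ccc3c(NCCCNCc4cc(F)ccc4OC)ccnc3c2)cc1` comes nearest, giving 5960 nM, a gap that stays within the scatter, while compound 2 `COc1ccc(F)cc1CNCCCNc1ccnc2cc(Cc3ccccc3)ccc12` gives 7990 nM, a gap that lies beyond it. One measured step joins two of these compounds: a 1.3-fold lower number from compound 2 to compound 3 (0.13 log units; within the scatter), the replacement of benzyl by 4-methoxyphenyl on an aromatic carbon of the shared core, and it did not move the number beyond the scatter.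

Compound 4 `COc1ccc(Oc2ccc3c(NCCCNCc4ccco4)ccnc3c2)cc1` differs from compound 1 in one place: 4-methoxyphenoxy in place of 4-(trifluoromethyl)phenyl on an aromatic carbon. Going by the values given here, no measured step swaps exactly these two groups, so the only guide is the step from compound 2 to compound 3, which also changed a group on an aromatic carbon of the shared core and stayed within the scatter. The expectation is therefore a change no larger than the scatter in this assay, with no firm direction. The estimate for compound 4 is 4500 nM, with a range from 1800 nM to 11000 nM. For compound 4 the expected step is a 1.3-fold higher number from compound 1 to compound 4 (0.11 log units; within the scatter).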

Compound 4, half-maximal effective concentration: 5300 nM
Compound 4: middle estimate off by 1.2-fold (0.07 log units), on the low side; the measured number falls inside the stated range.
By their numbers in this assay, from the lowest: compounds 1, 4, 3 and 2 (each within the scatter of the next, the first and the last beyond it).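

Putting 4-methoxyphenoxy in place of 4-(trifluoromethyl)phenyl on this aromatic carbon of the shared core gives a 1.5-fold higher number from compound 1 to compound 4 (0.18 log units; within the scatter) in this assay and so adds a second change at such a carbon to the earlier one, a 1.3-fold lower number from compound 2 to compound 3 (0.13 log units; within the scatter). Compared with the earlier step, this change is a different exchange on a different pair of compounds: three fluorine atoms leave, two oxygen atoms enter, and the count of hydrogen-bond acceptors in the group rises from 0 to 2, yet the number still stays within the scatter, so neither of the two steps at hand goes against the picture of a position that tolerates a swap of one large aromatic group for another in this cytotoxicity read-out. No measurement at hand bears on why the step is this small.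

As far as these compounds go, both steps exchange one group holding a six-membered aromatic ring for another, so it remains open whether a group without such a ring, such as an amine, a carboxylic acid or a nitrile, would shift the number beyond the scatter on this carbon. The compounds shown also leave open whether a longer chain in place of the one linking the core to its amine would change the number more than these aromatic swaps do.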